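A few compounds are considered here, and "the series" means these few. Any claim that something is new, unique, unknown or untested is made for them only; others in the source may bear on it.

Measured compounds in an assay on CHO-K1 cells for displacement of a labelled ligand from prostaglandin E2 receptor EP1 subtype (Homo sapiens); on this read-out lower numbers stand for stronger inhibition and higher numbers for weaker inhibition:
compound 1 `Cc1cc(C(=O)O)nn1Cc1cc(Br)ccc1OCc1ccccc1`, 6.46 nM
compound 2 `Cc1cc(C(=O)O)nn1Cc1cc(Br)ccc1OCc1ccc(F)cc1F`, 0.525 nM
compound 3 `Cc1cc(C(=O)O)nn1Cc1cc(Br)ccc1OCc1ccc(F)cc1`, 7.41 nM

Among these three, compound 2 gives the lowest number in this assay. The nearest measured compound is compound 1, with a 12-fold lower number from compound 1 to compound 2 (1.09 log units; beyond the scatter); the furthest is compound 3, with a 14-fold higher number from compound 2 to compound 3 (1.15 log units; beyond the scatter). Compound 1 and compound 3 lie close together, with a 1.1-fold higher number from compound 1 to compound 3 (0.06 log units; within the scatter).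

Compound 4 `Cc1cc(C(=O)O)nn1Cc1cc(Cl)ccc1OCc1ccc(F)cc1F` differs from compound 2 by chloro in place of bromo on an aromatic carbon. Among the measured compounds shown here, none of the measured steps touches this group: the two steps beyond the scatter, a 12-fold lower number from compound 1 to compound 2 (1.09 log units; beyond the scatter) and a 14-fold higher number from compound 2 to compound 3 (1.15 log units; beyond the scatter), concern a fluoro, as does the small step of a 1.1-fold higher number from compound 1 to compound 3 (0.06 log units; within the scatter). On these data alone, the exchange of bromo for chloro is untested in this set, and no step beyond the scatter is expected in this assay in either direction. The expected step of a 1.5-fold higher number from compound 2 to compound 4 (0.18 log units; within the scatter) is meant to stay within the scatter. Compound 4 is therefore estimated at 0.8 nM, with a range from 0.3 nM to 2.5 nM.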

Compound 4, half-maximal inhibitory concentration: < 2000 nM
Compound 4 gave a limit, no number; the forecaster's own chance of this, stated with the estimate: 2%; the middle value does not contradict the limit.
By their numbers in this assay, from the lowest: compound 2; then compounds 1 and 3 (each within the scatter of the next).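

In this assay, among the compounds shown here, compound 4 gave < 2000 nM, which is a limit and not a number, so no step from compound 2 to compound 4 can be read. The compounds shown leave open whether chloro in place of bromo on an aromatic carbon shifts this read-out, and in which direction.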